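The source may report more compounds than this note shows. Statements on the series, on what has been measured and on what is new or still open speak of the compounds shown alone.

Measured so far in an ADME assay on HepG2 cells (Homo sapiens) for cytotoxicity, read by luminescence, CellTiter-Glo and ATP content, with a stated time of 72 h; on this read-out higher numbers stand for an effect only at larger amounts of compound and lower numbers for an effect already at smaller amounts:
compound 1, `COc1cccc(CNCCCNc2ccnc3cc(Cc4ccccc4)ccc23)c1O`, 5720 nM
compound 2, `COc1ccc(F)cc1CNCCCNc1ccnc2cc(Cc3ccc(C#N)cc3)ccc12`, 6050 nM
compound 3, `COc1ccc(F)cc1CNCCCNc1ccnc2cc(Cc3ccccc3)ccc12`, 7990 nM

All three numbers sit close together, each gap within the scatter; compound 1 sits at one end of this narrow span. Compound 4, `COc1cccc(CNCCCNc2ccnc3cc(Cc4cccc(C(F)(F)F)c4)ccc23)c1O`, differs from compound 1 in one place: trifluoromethyl in place of hydrogen on an aromatic carbon. The step that bears on it most is the one on the same benzyl ring, a 1.3-fold higher number from compound 2 to compound 3 (0.12 log units; within the scatter), which was within the scatter. The other step, a 1.4-fold higher number from compound 1 to compound 3 (0.15 log units; within the scatter), touches a different part and was also within the scatter. Neither change of a group on these phenyl rings moved this assay. Compound 4 is therefore expected to change little, with a 1.0-fold lower number from compound 1 to compound 4 (0.00 log units; within the scatter), and its estimated value is 5700 nM, with a range from 2700 nM to 12000 nM.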

Compound 4, half-maximal effective concentration: 1720 nM
The estimate for compound 4 lay 3.3-fold (0.52 log units) above the measured number; measured number below the stated range.
By their numbers in this assay, from the lowest: compound 4; then compounds 1, 2 and 3 (each within the scatter of the next).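

In this assay, for the compounds shown here, trifluoromethyl in place of hydrogen on the benzyl ring gives a 3.3-fold lower number from compound 1 to compound 4 (0.52 log units; beyond the scatter), the first single change here to go beyond the scatter. On that ring, hydrogen in place of cyano gave only a 1.3-fold higher number from compound 2 to compound 3 (0.12 log units; within the scatter), so a change on this ring does not always leave the number where it was. Nothing available explains the shift.

Going by these compounds, it remains open whether a smaller group on the same aromatic carbon, such as methyl or chlorine, would lower the number too. It is also unclear whether trifluoromethyl would do the same alongside the 5-fluoro-2-methoxyphenyl group.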